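This account rests on a few compounds, and the source may have more. Where it says the series, first, only, none or still open, it means among the compounds named here.

In a functional assay on RKO cells (Homo sapiens) for cytotoxicity, read by MTT assay, with a stated time of 48 h (a higher number here means a weaker inhibitor, a lower number a stronger inhibitor), the measured compounds give:
compound 1 `CN(C)CCNc1ccnc2cc(OCc3ccc(F)cc3)ccc12`, 580 nM
compound 2 `CCCCCCCCOc1ccc2c(Cl)ccnc2c1`, 3640 nM
compound 3 `C=CCOc1ccc2c(NCCN(C)C)ccnc2c1`, 1270 nM

Compound 2 has the highest number of the three; compound 3 stands nearest to it and compound 1 furthest, both with lower numbers beyond the scatter. Compound 4 `CCOc1ccc2c(Cl)ccnc2c1` differs from compound 2 by hydrogen in place of hexyl on a saturated chain carbon, two bonds along the chain from an oxygen on an aromatic ring. Among the measured compounds shown here, no measured step shortens a chain in this way. For the measured compounds named here, the only measured step, a 2.2-fold higher number from compound 1 to compound 3 (0.34 log units; beyond the scatter), puts a smaller group in place of a larger one on a saturated chain carbon bound to an oxygen on an aromatic ring and raised the number modestly. On that basis a rise of similar or somewhat larger size in this assay is expected for compound 4, the step of a 2.5-fold higher number from compound 2 to compound 4 (0.39 log units; beyond the scatter). Compound 4 is therefore estimated at 9000 nM, within 2500 nM to 30000 nM.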

Compound 4, half-maximal inhibitory concentration: 3870 nM
For compound 4 the middle estimate is 2.3-fold (0.37 log units) above the measured one; the range from low to high includes it.
By their numbers in this assay, from the lowest: compound 1; then compound 3; then compounds 2 and 4 (each within the scatter of the next).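

In this assay, hydrogen in place of hexyl on a saturated chain carbon, two bonds along the chain from an oxygen on an aromatic ring, gives a 1.1-fold higher number from compound 2 to compound 4 (0.03 log units; within the scatter). Among the compounds shown here, at this position, then, the hexyl makes no difference that can be read for this pair, whereas the one earlier step, a 2.2-fold higher number from compound 1 to compound 3 (0.34 log units; beyond the scatter), at a saturated chain carbon bound to that oxygen, lay beyond the scatter. No available evidence bears on this result. Open remains whether an amine or a carboxylic acid at this place would read the same, and whether hydrogen in place of hexyl would give a like result on the core of compound 1.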